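Dropping the Chloro Group from Compound 2

The compounds below may be only part of what the source reports. "The series", "measured", "known", "first", "only" and "open" are said of these compounds alone.

Of the compounds shown here, three sharing one core have been tested in a functional assay on the whole organism for inhibition, with Echinochloa esculenta as the target; on this read-out lower numbers stand for stronger inhibition and higher numbers for weaker inhibition. Compound 1 `S=c1n(-c2ccc(Br)cc2)c(=S)n2n1CCCC2` gives 66.1 nM, compound 3 `Fc1cc(Cl)ccc1-n1c(=S)n2n(c1=S)CCCC2` gives 91.2 nM, and compound 2 `S=c1s/c(=N\c2ccc(Cl)cc2)n2n1CCCC2` gives 407 nM. Compound 2 thus shows the highest number of the three and is the weakest inhibitor, its gaps to compound 3 and to compound 1 both lying beyond the scatter. The unmeasured compound 4 `S=c1s/c(=N\c2ccccc2)n2n1CCCC2` differs from compound 2 by one change: hydrogen in place of chloro on an aromatic carbon. For the measured compounds named here, no measured pair shows this change, so its effect is open. Since the halogen-bearing compound 1 with 66.1 nM and compound 3 with 91.2 nM sit lower, a modest weakening is expected, a 1.5-fold higher number from compound 2 to compound 4 (0.17 log units; within the scatter). Compound 4 is estimated to give about 600 nM in this assay, in a range from 250 nM to 1500 nM.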

Compound 4, half-maximal inhibitory concentration: 15100 nM
The estimate for compound 4 lay 25-fold (1.40 log units) below the measured number; measured number outside the range, above it.
By their numbers in this assay, from the lowest: compounds 1 and 3 (each within the scatter of the next); then compound 2; then compound 4.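

Hydrogen in place of chloro on this aromatic carbon, para to a large group, brings a 37-fold higher number from compound 2 to compound 4 (1.57 log units; beyond the scatter) in this assay. This place on the ring is therefore far from indifferent to the change, and much of the inhibition shown by compound 2 is lost along with the chloro group. Nothing at hand accounts for the size of this loss.

Going by these compounds, whether a methoxy group or an amine at this place would restore the inhibition remains open. So does whether losing the halogen from compound 1 would cost as much.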